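A bromine on the benzyl arm of compound 2

The source may report more compounds than this note shows. Statements on the series, on what has been measured and on what is new or still open speak of the compounds shown alone.

Compound 1 `CCOC(=O)c1oc2ccc(NS(=O)(=O)c3ccc(Br)cc3)cc2c1C` carries a hydrogen on its sulfonamide nitrogen; in a functional assay on HCT-116 cells (Homo sapiens) for inhibition, read by MTT assay, with a stated time of 72 h (a higher number here means a weaker inhibitor, a lower number a stronger inhibitor), compound 1 gives > 40000 nM, which is a limit of the assay rather than a number. For the measured compounds named here, compound 2 `CCOC(=O)c1oc2ccc(N(Cc3ccccc3)S(=O)(=O)c3ccc(Br)cc3)cc2c1C` is the only compound with a true number here, giving 8700 nM. Going by the values given here, the single measured step is an at least 4.5-fold lower number from compound 1 to compound 2 (0.66 log units; beyond the scatter). Compound 3 `CCOC(=O)c1oc2ccc(N(Cc3ccc(Br)cc3)S(=O)(=O)c3ccc(Br)cc3)cc2c1C` differs from compound 2 by bromo in place of hydrogen on an aromatic carbon. Among the compounds with values here, no measured step touches a bromo on that ring, so the benzyl step gives no direct guide, and the change is expected to stay within the scatter. Compound 3 is therefore estimated at 6500 nM (range 2500 nM to 20000 nM), a step of a 1.3-fold lower number from compound 2 to compound 3 (0.13 log units; within the scatter).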

Compound 3, half-maximal inhibitory concentration: 5220 nM
For compound 3 the middle estimate is 1.2-fold (0.10 log units) above the measured one; low and high end bracket the measured number.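

Bromo on the benzyl arm gives a 1.7-fold lower number from compound 2 to compound 3 (0.22 log units; within the scatter), so in this assay this change does not separate the two compounds. With 4-bromobenzyl on the sulfonamide nitrogen, the drop from the hydrogen compound persists, with an at least 7.6-fold lower number from compound 1 to compound 3 (0.88 log units; beyond the scatter). That step is only a bound, because the value of compound 1 is a limit of the assay and not a number: the limit of > 40000 nM in this assay, at which 1 of the 3 values shown sits.

The compounds shown leave open whether an amine, a carboxylic acid or a longer chain in place of bromo on this ring would move the number beyond the scatter.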